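The source may hold more compounds than are shown below. What is called first, only, known or untested is meant among the compounds shown, and "the series" means these compounds.

In a functional assay on MDA-MB-231 cells (Homo sapiens) for antiproliferative activity, with a stated time of 48 h (on this read-out higher numbers stand for weaker inhibition and lower numbers for stronger inhibition), compound 1 (`CCOC(=O)c1ccc(-c2ccc(N(CC)CC)nn2)cc1`) gives 1500 nM. Compound 2 (`CCOC(=O)c1ccc(-c2ccc(OCC)nn2)cc1`) gives > 25000 nM, which is a limit and not a number. Compound 3 (`CCOC(=O)c1ccc(-c2ccc(OC(C)C)nn2)cc1`) differs from it by methyl in place of hydrogen on a saturated chain carbon bound to an oxygen on an aromatic ring and a saturated chain carbon, which turns ethoxy into isopropoxy. Within the data shown here, the only measured step, an at least 16-fold higher number from compound 1 to compound 2 (1.22 log units; beyond the scatter), is large, but it replaces diethylamino and ends at a limit, so it sets no size for this smaller change. No return to measurable activity is expected, and the expected result is a step that the limit leaves unreadable from compound 2 to compound 3, with no shift beyond the scatter. For compound 3 the estimate is 28000 nM, with an expected range of 10000 nM to 60000 nM.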

Compound 3, half-maximal inhibitory concentration: > 25000 nM
Compound 3 ended at the assay's limit (the forecaster's own chance of this, stated with the estimate: 75%); the middle value is on the limit's open side.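

In this assay, a second ether, isopropoxy, fares no better than ethoxy: adding methyl on this saturated chain carbon brings no measurable activity back. Replacing diethylamino with isopropoxy gives an at least 16-fold higher number from compound 1 to compound 3 (1.22 log units; beyond the scatter), so this large loss is not confined to ethoxy. Compound 3 sits at the same limit as compound 2, and the step between them cannot be read: the limit of > 25000 nM in this assay, at which 2 of the 3 values shown sit.

The compounds shown leave open whether another amine on this aromatic carbon, such as dimethylamino or pyrrolidine, would keep the activity of compound 1. Going by these compounds, how far compound 2 and compound 3 lie beyond the limit also stays unknown.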